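The source may hold more compounds than are shown below. What is called first, only, known or untested is meant among the compounds shown, and "the series" means these compounds.

Compound 1 `CCCCN(C)S(=O)(=O)NC(=O)Nc1c(C(C)C)cccc1C(C)C` gives 2300 nM in an assay on liver for inhibition of sterol O-acyltransferase 1 (Rattus norvegicus), using microsomes (a higher number here means a weaker inhibitor, a lower number a stronger inhibitor), the highest of the three numbers measured here; compound 2 `CC(C)CCN(CCC(C)C)S(=O)(=O)NC(=O)Nc1c(C(C)C)cccc1C(C)C` gives 420 nM and compound 3 `CCCCCCCCCCCCCCN(C)S(=O)(=O)NC(=O)Nc1c(C(C)C)cccc1C(C)C` gives 330 nM. Compound 4 `CCCCCCOS(=O)(=O)NC(=O)Nc1c(C(C)C)cccc1C(C)C` differs from compound 1 in one place: hexyloxy in place of butyl(methyl)amino on a sulfonyl sulfur. Among the measured compounds shown here, the only measured step touching that side of the molecule is the chain extension a 7.0-fold lower number from compound 1 to compound 3 (0.84 log units; beyond the scatter), which lowered the number. For the measured compounds named here, compound 4 also carries a longer chain, but it attaches through oxygen rather than nitrogen, and no measured pair covers that exchange, so the expectation is uncertain. For compound 4 a modest step of a 1.9-fold lower number from compound 1 to compound 4 (0.28 log units; within the scatter) is expected, giving an estimated 1200 nM with a likely range from 400 nM to 4000 nM.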

Compound 4, half-maximal inhibitory concentration: 27000 nM
For compound 4 the middle estimate is 23-fold (1.35 log units) below the measured one; measured number outside the range, above it.
By their numbers in this assay, from the lowest: compounds 3 and 2 (each within the scatter of the next); then compound 1; then compound 4.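

On the sulfonyl sulfur, hexyloxy in place of butyl(methyl)amino gives a 12-fold higher number from compound 1 to compound 4 (1.07 log units; beyond the scatter) in this assay and so makes a much weaker inhibitor. The earlier change on this side of the molecule, a 7.0-fold lower number from compound 1 to compound 3 (0.84 log units; beyond the scatter) and a stronger inhibitor, went the other way, so carrying a longer chain does not by itself lower the number at this position. Nothing available explains this loss.

The exchange alters both the attaching atom and the chain, and the compounds shown leave open which of the two matters. Hexyl(methyl)amino or butoxy on the same sulfur would separate them.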